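Cytotoxicity limit in the series and the step to compound 3

The source may hold more compounds than are shown below. What is called first, only, known or untested is meant among the compounds shown, and "the series" means these compounds.

Measured in an ADME assay on 2209-23 cells (Homo sapiens) for cytotoxicity, read by WST assay and thymidine incorporation; on this read-out lower numbers stand for higher toxicity in this test and higher numbers for lower toxicity in this test:
Compound 1 `CC(C)(C)[C@H]1C(O)=C(C2=CS(=O)(=O)c3cc(NS(C)(=O)=O)ccc3N2)C(=O)N1Cc1ccc(F)cc1`: > 50000 nM (a limit)
Compound 2 `CC(C)(C)[C@H]1C(O)=C(C2=CS(=O)(=O)c3cc(NS(C)(=O)=O)ccc3N2)C(=O)N1Cc1ccc(F)c(Cl)c1`: > 50000 nM (a limit)

In this assay compound 2 gives > 50000 nM, which is a limit and not a number. Both measured compounds stand at the same limit: the limit of > 50000 nM in this assay, at which 2 of the 2 values shown sit. Among the measured compounds shown here, the only measured step is a step that the two limits leave unreadable from compound 1 to compound 2, with chloro in place of hydrogen on an aromatic carbon. It gives no size to carry forward.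

Compound 3 `CC(C)CCN1C(=O)C(C2=CS(=O)(=O)c3cc(NS(C)(=O)=O)ccc3N2)=C(O)[C@@H]1C(C)(C)C` has not yet been measured. Its difference from compound 2 is isobutyl in place of 3-chloro-4-fluorophenyl on a saturated chain carbon bound to an amide-type nitrogen in a ring. In words, this is isobutyl in place of 3-chloro-4-fluorophenyl on a saturated chain carbon bound to an amide-type nitrogen in a ring.

For the measured compounds named here, no measured step covers this change, so the expectation rests only on the shared limit, (the limit of > 50000 nM in this assay, at which 2 of the 2 values shown sit). No shift in either direction beyond the scatter is expected in this assay. The expected result is a step that the limit leaves unreadable from compound 2 to compound 3. For compound 3 the estimate is 60000 nM, with an expected range from 25000 nM to 150000 nM. A further report of a limit is the expected outcome.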

Compound 3, half-maximal cytotoxic concentration: > 50000 nM
Compound 3 ended at the assay's limit; the forecaster's own chance of this, stated with the estimate: 80%; the middle value is on the limit's open side.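

In this assay compound 3 gives > 50000 nM as a limit, so no new step can be read from compound 1 or compound 2 to compound 3. All three compounds stand at the same limit: the limit of > 50000 nM in this assay, at which 3 of the 3 values shown sit.

Still open, as far as these compounds go, is whether any other group in this place would give a number rather than a limit in this assay.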